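Aryl amide series: methoxy to fluoro on the benzamide ring

This account rests on a few compounds, and the source may have more. Where it says the series, first, only, none or still open, it means among the compounds named here.

Going by the values given here, compound 1 `COc1cccc(C(=O)Nc2nc(-c3ccccn3)cs2)c1` holds the lowest of the two numbers so far in an ADME assay on Vero cells (Chlorocebus sabaeus) for cytotoxicity, read by MTT assay, with a stated time of 72 h; on this read-out lower numbers stand for an effect already at smaller amounts and higher numbers for an effect only at larger amounts of compound; in this assay compound 1 gives 2800 nM. Compound 2 `COc1ccc(C(=O)Nc2nc(-c3ccccn3)cs2)cc1` in this assay gives 9200 nM, a higher number, and the gap to compound 1 lies beyond the usual scatter. Among the compounds with values here, no pair of measured compounds isolates a single structural change, so no measured step is at hand.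

Compound 3 `O=C(Nc1nc(-c2ccccn2)cs1)c1cccc(F)c1` differs from compound 1 by fluoro in place of methoxy on an aromatic carbon. Within the data shown here, the measured data give no step for this exchange, and the two measured values show only that a change of substituent on that ring can shift the read-out beyond the scatter. The step in this assay from compound 1 to compound 3 is therefore expected to be small, with no clear direction, and likely within the scatter.

Compound 3 is estimated at 3500 nM, with a range from 1500 nM to 8000 nM. The expected step is a 1.3-fold higher number from compound 1 to compound 3 (0.10 log units; within the scatter).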

Compound 3, half-maximal effective concentration: 1200 nM
Beside the measured number, compound 3's estimate is 2.9-fold (0.46 log units) above it, and the stated range ends above it.
By their numbers in this assay, from the lowest: compound 3; then compound 1; then compound 2.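

In this assay the exchange of methoxy for fluoro at this place, on an aromatic carbon meta to a large group, gives a 2.3-fold lower number from compound 1 to compound 3 (0.37 log units; beyond the scatter) and so places compound 3 lowest of the three. Compounds 1 and 2 offered no single-change comparison, whereas this modest step ties a shift beyond the scatter to one exchange at one place, although it rests on a single pair. Nothing at hand bears on the reason for this shift.

As far as these compounds go, whether other groups at this place, such as an amine, a carboxylic acid or a longer chain, move the number in the same direction remains open. Also open, from the compounds shown here alone, is whether fluoro in place of methoxy on compound 2 gives a step of similar direction and size.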